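This account rests on a few compounds, and the source may have more. Where it says the series, first, only, none or still open, it means among the compounds named here.

In a functional assay on MDA-MB-231 cells (Homo sapiens) for antiproliferative activity, read by MTT assay, with a stated time of 48 h (a higher number here means a weaker inhibitor, a lower number a stronger inhibitor), compound 1 (`COc1ccc(N(C)c2ccnc(Cl)n2)cc1F`) gives 1280 nM and compound 2 (`COc1ccc(N(C)c2ccnc(Cl)n2)cc1Cl`) gives 1380 nM. These two differ only by chloro in place of fluoro on an aromatic carbon, and that step, a 1.1-fold higher number from compound 1 to compound 2 (0.03 log units; within the scatter), lies within the scatter. Compound 3 (`COc1ccc(N(C)c2cc(C)nc(C)n2)cc1F`) keeps the fluoro of compound 1 but differs from it elsewhere on the core. At 2790 nM, compound 3 has the highest number of the three, which makes it the weakest inhibitor of the set, and its distance from each of the other two lies beyond the scatter.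

The next change leads to compound 4 (`COc1ccc(N(C)c2cc(C)nc(C)n2)cc1O`), where hydroxy takes the place of fluoro: hydroxy in place of fluoro on an aromatic carbon. Within the data shown here, the only measured step at this aromatic carbon is the small one from fluoro to chloro, a 1.1-fold higher number from compound 1 to compound 2 (0.03 log units; within the scatter). Among the measured compounds shown here, it shows that one halogen can replace another with no visible effect in this assay, but no measured compound here carries a hydroxy group, so this evidence is only indirect. No step beyond the scatter is therefore expected, although the uncertainty is wide in both directions. The expected step is a 1.3-fold lower number from compound 3 to compound 4 (0.10 log units; within the scatter). For compound 4 the estimated value is 2200 nM, with an expected range from 600 nM to 8000 nM.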

Compound 4, half-maximal inhibitory concentration: 1100 nM
For compound 4 the middle estimate is 2.0-fold (0.30 log units) above the measured one, and the stated range covers the measured number.
By their numbers in this assay, from the lowest: compounds 4, 1 and 2 (each within the scatter of the next); then compound 3.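

In this assay, hydroxy in place of fluoro gives a 2.5-fold lower number from compound 3 to compound 4 (0.40 log units; beyond the scatter), so this aromatic carbon is not indifferent to the group it carries. The earlier exchange of one halogen for another, a 1.1-fold higher number from compound 1 to compound 2 (0.03 log units; within the scatter), showed no such shift, and it could not reveal this sensitivity: the position responds to a change from fluoro to hydroxy, a group counted with a hydrogen-bond donor and a hydrogen-bond acceptor, whereas fluoro is counted with neither. Nothing available here explains why the number falls, and the link between that count and the shift remains only a coincidence of two observations.

As far as these compounds go, this reading rests on a single pair of compounds, so it remains open whether hydroxy would give a similar shift on the core of compound 1, which differs from compound 3 elsewhere. It is also unknown how an amine or a carboxylic acid on this same aromatic carbon would compare with hydroxy, and such groups would help show whether the shift is particular to hydroxy or shared by other groups.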